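The source may hold more compounds than are shown below. What is called first, only, known or untested is meant among the compounds shown, and "the series" means these compounds.

Compound 1, `CCc1ccccc1NS(=O)(=O)c1cccc(NC(=O)NCCCCl)c1`; in a functional assay on M21 cells (Homo sapiens) for cytotoxicity, read by sulforhodamine B assay, with a stated time of 48 h (on this read-out higher numbers stand for weaker inhibition and lower numbers for stronger inhibition), compound 1 gives > 200000 nM, which is a limit of the assay rather than a number.
Compound 2, `CCNC(=O)Nc1cccc(S(=O)(=O)Nc2ccccc2C)c1`; in this assay compound 2 gives 131000 nM.

Within the data shown here, compound 2 stands as the only real number among the two results; the other value, that of compound 1, sits at the limit (the limit of > 200000 nM in this assay, at which 1 of the 2 values shown sits). Compound 3, `CCNC(=O)Nc1cccc(S(=O)(=O)Nc2ccccc2CC)c1`, is not yet measured. It differs from compound 2 by methyl in place of hydrogen on a saturated chain carbon bound to an aromatic carbon. Among the measured compounds shown here, no measured pair differs in just this way, so there is no step to lean on. Compound 1 carries the same ethyl group but differs from compound 3 elsewhere too, and its result shows only a limit. Both results are weak, so compound 3 is expected to stay weak as well, with the step of a 1.1-fold higher number from compound 2 to compound 3 (0.06 log units; within the scatter) expected to be small or none beyond the scatter. The estimate for compound 3 in this assay is 150000 nM, within 60000 nM to 400000 nM.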

Compound 3, half-maximal inhibitory concentration: > 100000 nM
Compound 3 was reported as a limit; the forecaster's own chance of this, stated with the estimate: 40%; the middle value is on the limit's open side.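

Compound 3 gives > 100000 nM, which is a limit of the assay and not a number, so the steps to compound 3 from compound 2 and from compound 1 cannot be read. The compounds shown leave open whether 2-ethylphenyl in place of 2-methylphenyl changes the result in this assay at all.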